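Working notes: 1-(hydroxymethyl)propyl in place of cyclohexyl

A few compounds are considered here, and "the series" means these few. Any claim that something is new, unique, unknown or untested is made for them only; others in the source may bear on it.

Of the compounds shown here, three have so far been tested in an assay on HEK293 cells for displacement of a labelled ligand from adenosine receptor A2b (Homo sapiens), read by scintillation counting, with a stated time of 30 min, tested at 10 uM; on this read-out lower numbers stand for less inhibition and higher numbers for more inhibition at the one concentration tested (going by the name of the read-out). Compound 1 `N=c1oc2ccc(Br)cc2cc1C(=O)NC1CCCCC1` gives 10% in this assay, the lowest of the three numbers. Compound 2 `COc1cccc2cc(C(=O)NCC(=O)O)c(=O)oc12` gives 35% in this assay, a number higher than that of compound 1 by more than the usual scatter. Compound 3 `COCCNC(=O)c1cc2cccc(OC)c2oc1=N` gives 43% in this assay, the highest of the three and again beyond the scatter from compound 1. Compounds 2 and 3 each differ from compound 1 in more than one place, so no single structural step can be read off from the measured compounds.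

Compound 4 `CCC(CO)NC(=O)c1cc2cc(Br)ccc2oc1=N` has not yet been measured. It differs from compound 1 in one place: 1-(hydroxymethyl)propyl in place of cyclohexyl on an amide-type nitrogen. Among the measured compounds shown here, no measured pair shows this change, so the expectation rests only on the spread of the three numbers, in which compound 1 with 10% sits at the bottom. A modest step upward in this assay is expected, at most slightly beyond the scatter, and a step of no size beyond the scatter would not be surprising.

The step from compound 1 to compound 4 is expected to be a number 10 percentage points higher from compound 1 to compound 4 (within the scatter). Compound 4 is estimated at 20% in this assay, with a range from 5% to 40%.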

Compound 4, a percentage reported as inhibition, at one concentration (the size of the read-out at that concentration, not a potency): 4%
Beside the measured number, compound 4's estimate is 16 percentage points above it, outside the stated range (below it).
By their numbers in this assay, from the lowest: compounds 4 and 1 (each within the scatter of the next); then compounds 2 and 3 (each within the scatter of the next).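

In this assay, among the compounds shown here, the first single-place step at this amide-type nitrogen reads a number 6 percentage points lower from compound 1 to compound 4 (within the scatter) on going from cyclohexyl to 1-(hydroxymethyl)propyl. At this position, then, the read-out does not separate a carbon-only six-membered ring from an open chain carrying a hydrogen-bond donor and acceptor, although the two groups differ in ring, atom make-up and hydrogen-bonding count. No available measurement bears on the reason for the size of this step.

As far as these compounds go, what remains open is which part of the exchange, if any, matters here, since loss of the ring and entry of the hydroxymethyl group arrive together in this one step; a plain propyl chain or a cyclohexyl ring bearing a hydroxymethyl group would pull those two apart. From the compounds shown here alone, it also remains open whether a primary amine or a carboxylic acid at the end of a longer chain on this nitrogen, with the rest of the core of compound 1 unchanged, would give a step beyond the scatter.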